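The source may report more compounds than this note shows. Statements on the series, on what has been measured and on what is new or still open speak of the compounds shown alone.

Series notes, clearance in an ADME assay on cells (Hepatocyte, Rattus norvegicus, strain Wistar Han) for pharmacokinetics, read by LC-MS, tested at 0.5 uM; on this read-out lower numbers stand for slow clearance and higher numbers for fast clearance.

Compound 1 `CNC(=O)c1cc(C(=O)N[C@@H]2C[C@H]2CO)cc2c1O[C@H](CF)[C@H]2c1ccccc1` carries a fluoromethyl on the shared core and a hydroxymethyl on the cyclopropyl amide; in this assay compound 1 gives 1.65 mL/min. Compound 2 `CNC(=O)c1cc(C(=O)NC2CC2)cc2c1O[C@H](CO)[C@H]2c1ccccc1` carries a hydroxymethyl on the core and a plain cyclopropyl amide. For compound 2 this assay reports only a limit, < 0.8 mL/min, so the value sits at the floor of what can be resolved (the limit of < 0.8 mL/min in this assay, at which 1 of the 2 values shown sits). Among the measured compounds shown here, of the two, compound 2 is the one at that floor while compound 1 stands at a measured number; no step between them is worked out here, and their structures differ in two places.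

Compound 3 `CNC(=O)c1cc(C(=O)NC2CC2)cc2c1O[C@H](C)[C@H]2c1ccccc1` differs from compound 2 in one place: hydrogen in place of hydroxy on a saturated chain carbon bound to a saturated ring carbon. Losing the hydroxy is expected to move clearance upward, the step from compound 2 to compound 3 being estimated at an at least 1.8-fold higher number from compound 2 to compound 3 (0.27 log units; that floor lies within the scatter), beyond the usual scatter. Compound 3 is expected at 1.5 mL/min, within 0.7 mL/min to 3.2 mL/min.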

Compound 3, intrinsic clearance in a liver preparation (reported as CLH), per the amount of preparation that the assay uses in the Hepatocyte assay: 2.48 mL/min
Compound 3: the middle estimate sits 1.7-fold (0.22 log units) below what was measured; the range from low to high includes it.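

In the Hepatocyte assay the change from hydroxymethyl to methyl gives the first readable step at this position, an at least 3.1-fold higher number from compound 2 to compound 3 (0.49 log units; beyond the scatter), a step taken from a limit: the limit of < 0.8 mL/min in the Hepatocyte assay, at which 1 of the 3 values shown sits.

In a physicochemical assay for solubility (on this read-out higher numbers stand for higher solubility and lower numbers for lower solubility), compound 2 gives > 177 ug/mL, which is also a limit. In the physicochemical assay compound 3 gives 137 ug/mL, and the step read from that limit is an at least 1.2-fold lower number from compound 2 to compound 3 (0.11 log units; that floor lies within the scatter), so on this read-out the same change leaves the two compounds unseparated.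

From the compounds shown here alone, how far compound 2 lies past either limit stays open, so neither step has a true size yet. Going by these compounds, compound 1 carries its fluoromethyl alongside a second difference, which leaves that group without a step of its own, and whether an aminomethyl or a methoxymethyl at this place would track hydroxymethyl or methyl remains unknown.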